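Swapping furan-3-yl for thiophen-2-yl: a second test

A few compounds are considered here, and "the series" means these few. Any claim that something is new, unique, unknown or untested is made for them only; others in the source may bear on it.

Compound 1 `COC(=O)C1=C(C)NC(=S)NC1c1ccoc1` and compound 2 `COC(=O)C1=C(C)NC(=S)NC1c1cccs1` share one core and differ in a single group. In an assay on membranes from HEK293 cells for displacement of a labelled ligand from adenosine receptor A2b (Homo sapiens), read by scintillation counting, with a stated time of 30 min, tested at 1 uM (a higher number here means more inhibition at the concentration tested (going by the name of the read-out), a lower number less inhibition), compound 1 gives 48%, and compound 2 gives 10%. The change is thiophen-2-yl in place of furan-3-yl on a saturated ring carbon, and it brought a number 38 percentage points lower from compound 1 to compound 2 (beyond the scatter).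

Compound 3 `CCC(CC)OC(=O)C1=C(C)NC(=O)NC1c1ccoc1` has a different core; how the core of compound 1 and the core of compound 3 differ is not broken down here. In this assay compound 3 gives 28%. Compound 4 `CCC(CC)OC(=O)C1=C(C)NC(=O)NC1c1cccs1` has not been measured. It stands to compound 3 as compound 2 stands to compound 1, through (thiophen-2-yl in place of furan-3-yl on a saturated ring carbon). The surroundings are not identical: in compound 1 the changed carbon is next to the ring atom that bears a methoxycarbonyl group, in compound 3 next to the ring atom that bears a group of 8 heavy atoms, so this is the same kind of change rather than the same change.

For compound 4 a step of a number 22 percentage points lower from compound 3 to compound 4 (beyond the scatter) is expected, smaller than the earlier one because a number 38 percentage points lower from compound 1 to compound 2 (beyond the scatter) began from a higher starting number than compound 3 offers. Compound 4 is estimated to give 6%, expected to lie between 0% and 20%.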

Compound 4, a percentage reported as inhibition, at one concentration (the size of the read-out at that concentration, not a potency): 6%
For compound 4 middle estimate and measured number coincide at the digits printed; measured number inside the range.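

Replacing furan-3-yl with thiophen-2-yl on the core of compound 3 gave a number 22 percentage points lower from compound 3 to compound 4 (beyond the scatter) in this assay. The change therefore lowered the number on both cores, but it did not carry over with the same size: the same change on two cores in this assay, a number 38 percentage points lower (beyond the scatter) from compound 1 to compound 2 and a number 22 percentage points lower (beyond the scatter) from compound 3 to compound 4, 16 percentage points apart, beyond the scatter of two such steps. Two pairs show only that the direction held in these two cases, not that it would hold on a further core, and they do not explain why the two steps differ in size.

The compounds shown leave open how other groups would behave on this saturated ring carbon, such as furan-2-yl, thiophen-3-yl, a phenyl ring or a ring carrying an amine. They also leave open which difference between the two cores goes with the difference in step size, including whether the methoxycarbonyl group or the group of 8 heavy atoms plays any part.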